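Methyl on the aromatic nitrogen of compound 2

The compounds below may be only part of what the source reports. "The series", "measured", "known", "first", "only" and "open" are said of these compounds alone.

For the measured compounds named here, compound 2 `COc1cc(/C=C/c2c[nH]c3ccccc23)cc(OC)c1OC` gives 3230 nM in a functional assay on P388 cells (Mus musculus) for inhibition (a higher number here means a weaker inhibitor, a lower number a stronger inhibitor), and holds the only actual number so far. Compound 1 `COc1cc(/C=C/c2cn(C(C)=O)c3ccccc23)cc(OC)c1OC` shows > 5000 nM in this assay as a limit, not a number. Going by the values given here, the one measured step, hydrogen in place of acetyl on an aromatic nitrogen, is an at least 1.5-fold lower number from compound 1 to compound 2 (0.18 log units; that floor lies within the scatter) and offers only a floor within the scatter, not a firm size. Among the compounds with values here, compound 3 `COc1cc(/C=C/c2cn(C)c3ccccc23)cc(OC)c1OC` carries methyl in place of hydrogen on an aromatic nitrogen as its single change. Within the data shown here, with compound 2 at 3230 nM and only that one measured step to go on, no shift beyond the scatter is expected in either direction. The expected step of a 1.1-fold lower number from compound 2 to compound 3 (0.03 log units; within the scatter) is accordingly small. For compound 3 the estimated value is 3000 nM in this assay, with an expected range from 1200 nM to 6500 nM for repeated measurements.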

Compound 3, half-maximal inhibitory concentration: 3090 nM
Beside the measured number, compound 3's estimate is 1.0-fold (0.01 log units) below it; low and high end bracket the measured number.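

On the aromatic nitrogen, methyl in place of hydrogen gives a 1.0-fold lower number from compound 2 to compound 3 (0.02 log units; within the scatter) in this assay, so losing the hydrogen on this nitrogen leaves the number within the scatter. Methyl in place of acetyl gives an at least 1.6-fold lower number from compound 1 to compound 3 (0.20 log units; that floor lies within the scatter), which again offers only a floor and does not separate the two groups. Compound 1 stands at a limit and not at a number, so the true size of both steps from it stays unknown: the limit of > 5000 nM in this assay, at which 1 of the 3 values shown sits.

The compounds shown leave open whether a longer chain such as propyl, a benzyl group or a chain ending in an amine on this nitrogen would stay level with compound 2 and compound 3. They also leave open whether any group at this position can move the number beyond the scatter.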